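The source may report more compounds than this note shows. Statements on the series, on what has been measured and on what is new or still open speak of the compounds shown alone.

Measured so far:

Compound 1 `CCCOc1cc(CNc2nc3c(N)ncnc3n2[C@@H]2O[C@H](CO)[C@@H](O)[C@H]2O)ccc1-c1ccccc1` — in an assay on COS-7 cells for inhibition of sodium/nucleoside cotransporter 2 (Homo sapiens), read by scintillation counting (a higher number here means a weaker inhibitor, a lower number a stronger inhibitor), compound 1 gives 5200 nM.

Compound 2 `NC(=O)COc1cc(CNc2nc3c(N)ncnc3n2[C@@H]2O[C@H](CO)[C@@H](O)[C@H]2O)ccc1-c1ccccc1` — in this assay compound 2 gives 5500 nM.

Compound 2 sits within the scatter of compound 1, so the two cannot be told apart on these numbers. Within the data shown here, the only step measured, a 1.1-fold higher number from compound 1 to compound 2 (0.02 log units; within the scatter), shows that changing the group on the saturated chain carbon bound to an oxygen on the aromatic ring left the number essentially where it was.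

Compound 3 `Nc1ncnc2c1nc(NCc1ccc(-c3ccccc3)c(OCCCCO)c1)n2[C@@H]1O[C@H](CO)[C@@H](O)[C@H]1O` carries the change (3-hydroxypropyl in place of carbamoyl on a saturated chain carbon bound to an oxygen on an aromatic ring), at the same place as that step. With one step at this place that lay within the scatter, and no other evidence, compound 3 is expected to stay close to compound 2, so the expected step of a 1.1-fold lower number from compound 2 to compound 3 (0.04 log units; within the scatter) is none beyond the scatter. Compound 3 is therefore estimated at 5000 nM, most likely between 2000 nM and 13000 nM.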

Compound 3, half-maximal inhibitory concentration: 940 nM
Estimate against measurement, compound 3: 5.3-fold (0.73 log units) above; measured number below the stated range.
By their numbers in this assay, from the lowest: compound 3; then compounds 1 and 2 (each within the scatter of the next).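

The position is not indifferent to its group: in this assay, 3-hydroxypropyl in place of carbamoyl on a saturated chain carbon bound to an oxygen on an aromatic ring gives a 5.9-fold lower number from compound 2 to compound 3 (0.77 log units; beyond the scatter), whereas the earlier step stayed within the scatter. Hydroxymethyl in place of hydrogen on a saturated chain carbon, three bonds along the chain from an oxygen on an aromatic ring, gives a 5.5-fold lower number from compound 1 to compound 3 (0.74 log units; beyond the scatter), so compound 3 is the strongest inhibitor of the three. No measurement at hand explains this drop.

The compounds shown leave open whether the gain follows the hydroxyl or the longer chain, a question a plain butyl chain would help to settle. Going by these compounds, how an amine or a carboxylic acid at the chain end would read also remains open.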